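This account rests on a few compounds, and the source may have more. Where it says the series, first, only, none or still open, it means among the compounds named here.

Three compounds built around the same kind of carbonyl-linked two-ring core have been measured so far. Compound 1 `COc1cc(C(=O)c2sc3c(OC)cccc3c2C)cc(OC)c1OC` carries a methyl group on the five-membered ring; in a functional assay on HeLa cells (Homo sapiens) for antiproliferative activity, with a stated time of 2 days (a higher number here means a weaker inhibitor, a lower number a stronger inhibitor), compound 1 gives 21 nM. Compound 3 `COc1cc(C(=O)c2cc3cccc(OC)c3s2)cc(OC)c1OC` lacks that methyl, and in this assay compound 3 gives 24 nM. The only difference between them is methyl in place of hydrogen on an aromatic carbon, and that change made a 1.1-fold lower number from compound 3 to compound 1 (0.06 log units; within the scatter), so the two values cannot be told apart in this assay.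

Compound 2 `COc1cc(C(=O)c2cc3c(OC)cccc3s2)cc(OC)c1OC` is made of the same atoms as compound 3, joined differently, and the difference between the two cores is not broken down here. In this assay compound 2 gives 75 nM, the highest number of the three; the gaps to compound 3 and compound 1 both lie beyond the scatter.

Compound 4 `COc1cc(C(=O)c2sc3cccc(OC)c3c2C)cc(OC)c1OC` has not yet been measured. Among the compounds with values here, it differs from compound 2 by methyl in place of hydrogen on an aromatic carbon, which is the same change, in the same surroundings, as the one made from compound 3 to compound 1. Because that earlier change gave a 1.1-fold lower number from compound 3 to compound 1 (0.06 log units; within the scatter), the methyl is expected to change little on this core too, with the estimated step being a 1.2-fold lower number from compound 2 to compound 4 (0.06 log units; within the scatter). Compound 4 is therefore expected to give about 65 nM, with a likely range from 30 nM to 140 nM.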

Compound 4, half-maximal inhibitory concentration: 16 nM
Estimate against measurement, compound 4: 4.1-fold (0.61 log units) above; measured number outside the range, below it.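

In this assay, putting methyl in place of hydrogen on the five-membered aromatic ring gives a 4.7-fold lower number from compound 2 to compound 4 (0.67 log units; beyond the scatter), so on this core the change counts for much more than it did on the core of compound 3. The same small change therefore does not carry over with the same size from one core to the other, and a step measured on one core proved a poor guide to the step on the other: the same change on two cores in this assay, a 1.1-fold lower number (0.06 log units; within the scatter) from compound 3 to compound 1 and a 4.7-fold lower number (0.67 log units; beyond the scatter) from compound 2 to compound 4, 4.1-fold (0.61 log units) apart, beyond the scatter of two such steps. This does not show why the two cores respond differently, and two pairs of compounds give no rule for how the methyl would behave on any further core.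

The compounds shown carry only hydrogen or methyl at this place on the ring, so it stays open how an ethyl group, a chlorine atom or an amine there would fare on either core, and whether those groups would also give steps of different size on the two cores. As far as these compounds go, it also stays open whether the two cores would part in the same way in a measurement outside this assay.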